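Shortening the amide on a 5-HT1F ligand core

The compounds below may be only part of what the source reports. "The series", "measured", "known", "first", "only" and "open" are said of these compounds alone.

Compound 1 `CCN1CC=C(c2c[nH]c3ccc(NC(=O)c4ccc(F)cc4)nc23)CC1`: 25 nM
Compound 2 `CCN1CCC(c2c[nH]c3ccc(NC(=O)c4ccc(F)cc4)nc23)CC1`: 170 nM
Compound 3 `O=C(Nc1ccc2[nH]cc(C3CCNCC3)c2n1)c1ccc(F)cc1`: 9.5 nM

In an assay for binding affinity to 5-hydroxytryptamine receptor 1F (Homo sapiens), read by radioligand binding (a lower number here means a stronger inhibitor, a higher number a weaker inhibitor), compound 3 gives the lowest number of the three: the step of a 2.6-fold lower number from compound 1 to compound 3 (0.42 log units; beyond the scatter) and the step of an 18-fold lower number from compound 2 to compound 3 (1.25 log units; beyond the scatter) both run downward to it. Compound 4 `CC(=O)Nc1ccc2[nH]cc(C3CCNCC3)c2n1` keeps the core of compound 3 and changes only the amide: methyl in place of 4-fluorophenyl on a carbonyl carbon. Within the data shown here, none of the measured steps touches this part of the molecule; the steps of a 6.8-fold higher number from compound 1 to compound 2 (0.83 log units; beyond the scatter), a 2.6-fold lower number from compound 1 to compound 3 (0.42 log units; beyond the scatter) and an 18-fold lower number from compound 2 to compound 3 (1.25 log units; beyond the scatter) all concern the ring on the aromatic carbon. The expectation for compound 4 is therefore a modest upward step, an 11-fold higher number from compound 3 to compound 4 (1.02 log units; beyond the scatter), with wide uncertainty. Compound 4 is estimated at 100 nM, within 25 nM to 400 nM.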

Compound 4, inhibition constant: 45 nM
For compound 4 the middle estimate is 2.2-fold (0.35 log units) above the measured one, and the stated range covers the measured number.
By their numbers in this assay, from the lowest: compound 3; then compounds 1 and 4 (each within the scatter of the next); then compound 2.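

Methyl in place of 4-fluorophenyl on a carbonyl carbon gives a 4.7-fold higher number from compound 3 to compound 4 (0.68 log units; beyond the scatter) in this assay and is the only step shown at the amide. The aromatic ring on the carbonyl therefore adds to binding but is not required for it, since compound 4 still gives 45 nM without that ring. Nothing shown explains the rise in the number.

From the compounds shown here alone, an unsubstituted phenyl, a propyl chain or a cyclopropyl on the same carbonyl carbon remains open. So does whether an ethyl on the ring nitrogen would change the number in the same way alongside the methyl amide.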